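The source may report more compounds than this note shows. Statements on the series, on what has been measured and on what is new or still open speak of the compounds shown alone.

In an ADME assay on HepG2 cells (Homo sapiens) for cytotoxicity, read by luminescence, CellTiter-Glo and ATP content, with a stated time of 72 h (on this read-out lower numbers stand for an effect already at smaller amounts and higher numbers for an effect only at larger amounts of compound), compound 1 `COc1ccc(Oc2ccc3c(NCCCNCc4cc(F)ccc4OC)ccnc3c2)cc1` gives 7000 nM. Within the data shown here, compound 2 `COc1ccc(F)cc1CNCCCNc1ccnc2cc(C3CCCCC3)ccc12` gives 2290 nM, and the one step between these two is a 3.1-fold lower number from compound 1 to compound 2 (0.49 log units; beyond the scatter). Compound 3 `COc1cccc(CNCCCNc2ccnc3cc(Cc4ccccc4)ccc23)c1O` gives 5720 nM, the second highest of the three numbers: its value differs from that of compound 1 by less than the usual scatter, while compound 2 gives a number that is lower by more than the scatter.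

Compound 4 `COc1cccc(CNCCCNc2ccnc3cc(Oc4ccccc4)ccc23)c1O` differs from compound 3 in one place: phenoxy in place of benzyl on an aromatic carbon. Among the measured compounds shown here, no measured step exchanges a benzyl for a phenoxy group anywhere in this set. For the measured compounds named here, the only step that changes a group at the same position of the core is a 3.1-fold lower number from compound 1 to compound 2 (0.49 log units; beyond the scatter), and it concerns other groups, so it bears on the new change only loosely. Compound 1, which carries a 4-methoxyphenoxy group at that position, gives 7000 nM, a number within the scatter of compound 3. On that basis compound 4 is expected to show a step of a 1.0-fold lower number from compound 3 to compound 4 (0.02 log units; within the scatter), which is no more than the scatter allows in either direction. The estimate for compound 4 is therefore 5500 nM, with a range from 2500 nM to 12000 nM.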

Compound 4, half-maximal effective concentration: 6800 nM
Beside the measured number, compound 4's estimate is 1.2-fold (0.09 log units) below it, and the stated range covers the measured number.
By their numbers in this assay, from the lowest: compound 2; then compounds 3, 4 and 1 (each within the scatter of the next).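

The exchange of benzyl for phenoxy on this aromatic carbon gives a 1.2-fold higher number from compound 3 to compound 4 (0.08 log units; within the scatter) in this assay, so compound 3 and compound 4 cannot be told apart on this read-out, although the entering group brings an oxygen and a hydrogen-bond acceptor that the leaving group lacks. The earlier step at this position, cyclohexyl in place of 4-methoxyphenoxy, gave a 3.1-fold lower number from compound 1 to compound 2 (0.49 log units; beyond the scatter) and lay beyond the scatter, but it was made on a different benzyl group and replaced the aromatic ring itself; the new pair shows that, with the six-membered aromatic ring kept and the heavy-atom count equal, this exchange produces no step beyond the scatter. Nothing available explains this result.

The compounds shown leave open whether an aniline-type amine link or a phenyl ring attached directly at this position would also stay within the scatter of compound 3, and whether a carboxylic acid on the phenoxy ring would move the number. They also leave open whether benzyl and phenoxy would read alike when paired with the fluorine-bearing benzyl group of compound 1 and compound 2.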